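The source may hold more compounds than are shown below. What is called first, only, known or untested is meant among the compounds shown, and "the series" means these compounds.

Measured so far:
compound 1, `Nc1nc(O)c2c(n1)n(C1OC(CO)[C@@H](O)[C@H]1O)c(=O)n2C/C=C/c1ccccc1`, 103 uM in a functional assay (B cells) with Mus musculus as the target; a lower number here means that less compound is needed, a higher number that more compound is needed for the effect
compound 2, `C=CCn1c(=S)n(C2OC(CO)[C@@H](O)C(O)[C@H]2O)c2nc(N)nc(O)c21`, 1 uM in this assay

Compound 1 stands at the highest of the two numbers in this assay; compound 2 gives the lower value, and the two values lie well beyond the scatter of each other. Within the data shown here, no single-point step between measured compounds is available here. Compound 3, `Nc1nc(O)c2c(n1)n(C1OC(CO)[C@@H](O)[C@H]1O)c(=O)n2Cc1ccccc1`, is not yet measured; it differs from compound 1 in one place: phenyl in place of 2-phenylethenyl on a saturated chain carbon bound to an aromatic nitrogen. Among the measured compounds shown here, with no measured step of this kind to lean on, the step of a 1.2-fold higher number from compound 1 to compound 3 (0.07 log units; within the scatter) is expected to stay within the scatter. Compound 3 is therefore estimated at 120 uM, with a range from 30 uM to 400 uM.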

Compound 3, concentration for half-maximal effect: 6 uM
Beside the measured number, compound 3's estimate is 20-fold (1.30 log units) above it, and the stated range ends above it.
By their numbers in this assay, from the lowest: compound 2; then compound 3; then compound 1.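

At this position, on a saturated chain carbon bound to an aromatic nitrogen, the outer group clearly matters in this assay: phenyl in place of 2-phenylethenyl gives a 17-fold lower number from compound 1 to compound 3 (1.23 log units; beyond the scatter). Both groups carry the same six-membered aromatic ring, so the difference lies in the double bond and the longer chain that leave with 2-phenylethenyl. Nothing available accounts for the size of this step.

This single pair cannot separate the double bond from the chain length, which 2-phenylethyl could address. From the compounds shown here alone, how an amine or a carboxylic acid would fare in place of phenyl also remains open.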